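The compounds below may be only part of what the source reports. "The series", "measured", "known", "first", "only" and "open" are said of these compounds alone.

Compound 2 `CN(C)CCn1cnnc1-c1cc(Oc2ccc(NC(=O)N/N=C/c3ccccc3O[N+](=O)[O-])cc2F)ccn1` gives the lowest number of the three in a functional assay on HT-29 cells (Homo sapiens) for cytotoxicity, read by MTT assay, with a stated time of 72 h (a lower number here means a stronger inhibitor, a higher number a weaker inhibitor), at 950 nM. Compound 1 `COc1ccc(/C=N/NC(=O)Nc2ccc(Oc3ccnc(-c4nncn4CCN(C)C)c3)c(F)c2)c(OC)c1OC` gives 3970 nM in this assay, and compound 3 `Cn1ncnc1-c1cc(Oc2ccc(NC(=O)N/N=C/c3ccccc3)cc2F)ccn1` gives 30200 nM in this assay. Compound 4 `COc1cc(/C=N/NC(=O)Nc2ccc(Oc3ccnc(-c4nncn4CCN(C)C)c3)c(F)c2)cc(OC)c1OC` carries 3,4,5-trimethoxyphenyl in place of 2-(nitrooxy)phenyl on a carbon with a double bond to nitrogen. For the measured compounds named here, the only measured step that bears on this change is a 4.2-fold lower number from compound 1 to compound 2 (0.62 log units; beyond the scatter), which replaced a trimethoxyphenyl with the nitrooxyphenyl; compound 4 brings a trimethoxyphenyl back, though not the same one as in compound 1. A modest rise in the number is therefore expected, roughly undoing that step. Compound 4 is expected at 3500 nM, with a range from 1200 nM to 10000 nM. The expected step in this assay is a 3.7-fold higher number from compound 2 to compound 4 (0.57 log units; beyond the scatter).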

Compound 4, half-maximal inhibitory concentration: 3620 nM
Estimate against measurement, compound 4: 1.0-fold (0.01 log units) below; the range from low to high includes it.
By their numbers in this assay, from the lowest: compound 2; then compounds 4 and 1 (each within the scatter of the next); then compound 3.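

In this assay, the second trimethoxyphenyl pattern also stands apart from 2-(nitrooxy)phenyl on this carbon, with a 3.8-fold higher number from compound 2 to compound 4 (0.58 log units; beyond the scatter). The two trimethoxyphenyl patterns are not told apart here, with a 1.1-fold lower number from compound 1 to compound 4 (0.04 log units; within the scatter), so this arrangement of the three methoxy groups makes no visible difference in this pair. Nothing available gives a reason for the gap to compound 2. Still open, as far as these compounds go, is whether the number of compound 2 depends on the nitrooxy group itself, as a hydroxyphenyl or a nitrophenyl on this carbon could show.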